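From naphthalen-1-yl to phenyl on the amine nitrogen

This account rests on a few compounds, and the source may have more. Where it says the series, first, only, none or still open, it means among the compounds named here.

Three analogues sharing one core differ only in the aryl group on an amine nitrogen. Compound 1 `C=C1[C@@H](OC(C)=O)C[C@@H]2[C@](C)(COC=O)[C@H](OC(C)=O)CC[C@@]2(C)[C@@H]1C[C@@H](Nc1ccccc1C(=O)O)C1=CCOC1=O` gives 28700 nM in a functional assay on HT-29 cells (Homo sapiens) for cytotoxicity, read by sulforhodamine B assay; on this read-out higher numbers stand for weaker inhibition and lower numbers for stronger inhibition. Compound 2 `C=C1[C@@H](OC(C)=O)C[C@@H]2[C@](C)(COC=O)[C@H](OC(C)=O)CC[C@@]2(C)[C@@H]1C[C@@H](Nc1ccc(O)cc1)C1=CCOC1=O` gives 13400 nM in this assay, and compound 3 `C=C1[C@@H](OC(C)=O)C[C@@H]2[C@](C)(COC=O)[C@H](OC(C)=O)CC[C@@]2(C)[C@@H]1C[C@@H](Nc1cccc2ccccc12)C1=CCOC1=O` gives 8670 nM, the lowest of the three numbers, although compound 2 sits within the usual scatter of it. The measured steps were a 2.1-fold lower number from compound 1 to compound 2 (0.33 log units; beyond the scatter), a 3.3-fold lower number from compound 1 to compound 3 (0.52 log units; beyond the scatter) and a 1.5-fold lower number from compound 2 to compound 3 (0.19 log units; within the scatter).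

Compound 4 `C=C1[C@@H](OC(C)=O)C[C@@H]2[C@](C)(COC=O)[C@H](OC(C)=O)CC[C@@]2(C)[C@@H]1C[C@@H](Nc1ccccc1)C1=CCOC1=O` carries phenyl in place of naphthalen-1-yl on an amine nitrogen. Both steps that lead into compound 3 bear on this change, since each brings naphthalen-1-yl in: one modest, one within the scatter. Removing the second ring is therefore expected to undo at most a small part of that, and the number for compound 4 in this assay is estimated to rise by a 1.6-fold higher number from compound 3 to compound 4 (0.21 log units; within the scatter). For compound 4 the expected value is 14000 nM, with a range from 6000 nM to 35000 nM.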

Compound 4, half-maximal inhibitory concentration: 28800 nM
For compound 4 the middle estimate is 2.1-fold (0.31 log units) below the measured one; the measured number falls inside the stated range.
By their numbers in this assay, from the lowest: compounds 3 and 2 (each within the scatter of the next); then compounds 1 and 4 (each within the scatter of the next).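

Taking away the second ring of naphthalen-1-yl is not neutral in this assay: the change gives a 3.3-fold higher number from compound 3 to compound 4 (0.52 log units; beyond the scatter), so phenyl alone on the amine nitrogen does not keep the lower number. The substituent on that phenyl also counts, but not every one does: hydrogen in place of hydroxy on an aromatic carbon gives a 2.1-fold higher number from compound 2 to compound 4 (0.33 log units; beyond the scatter), whereas hydrogen in place of carboxy gives a 1.0-fold higher number from compound 1 to compound 4 (0.00 log units; within the scatter), so the carboxy group shows no effect beyond the scatter. No measurement shown accounts for these differences.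

On these data alone, whether methoxy or an amine in place of hydroxy on the aromatic carbon would match compound 2 remains open. So does whether naphthalen-2-yl on the amine nitrogen would match compound 3.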